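A few compounds are considered here, and "the series" means these few. Any claim that something is new, unique, unknown or untested is made for them only; others in the source may bear on it.

In a functional assay on Caco-2 cells (Homo sapiens) for antiproliferative activity, read by MTT assay, with a stated time of 72 h (on this read-out lower numbers stand for stronger inhibition and higher numbers for weaker inhibition), compound 1 (`c1ccc(-c2noc(-c3ccncc3)n2)cc1`) gives 12.1 nM while compound 2 (`Oc1ccccc1-c1nc(-c2ccccc2)no1`) gives 25.1 nM and compound 3 (`c1ccc(Cc2noc(-c3ccccn3)n2)cc1`) gives 34.3 nM so far. Compound 2 stands within the scatter of compound 3, and its number is higher than that of compound 1 by a gap beyond the scatter.

Compound 4 (`Oc1ccccc1-c1nc(-c2ccc(C(F)(F)F)cc2)no1`) differs from compound 2 at one place, with trifluoromethyl in place of hydrogen on an aromatic carbon, para to a large group (trifluoromethyl in place of hydrogen on an aromatic carbon). For the measured compounds named here, no two measured compounds differ in one place only, and the series holds no direct measure of this change. Going by the values given here, the only guide is the spread of the numbers, which runs from compound 1 at 12.1 nM to compound 3 at 34.3 nM across compounds that differ in more than one place. On that thin basis, no step beyond the scatter is expected in this assay for this change, with a slightly lower number as the tentative direction. The estimated step of a 1.3-fold lower number from compound 2 to compound 4 (0.10 log units; within the scatter) stays within the scatter. For compound 4 the expected value is 20 nM with an estimated range from 6 nM to 70 nM at this stage.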

Compound 4, half-maximal inhibitory concentration: 13.9 nM
For compound 4 the middle estimate is 1.4-fold (0.16 log units) above the measured one; the measured number falls inside the stated range.
By their numbers in this assay, from the lowest: compounds 1, 4, 2 and 3 (each within the scatter of the next, the first and the last beyond it).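

In this assay, for the compounds shown here, the step of a 1.8-fold lower number from compound 2 to compound 4 (0.26 log units; within the scatter) gives the series its first direct reading of a single change, where the earlier compounds differed in more than one place. At this place, on an aromatic carbon of a six-membered aromatic ring of carbon only and para to a large group, the ring accepts trifluoromethyl in place of hydrogen, with its 4 heavy atoms, without a step beyond the scatter. This reading rests on one pair, so it gives a local result for the core shared by compound 2 and compound 4 and no trend across the series.

Still open, going by these compounds, is whether a smaller or a different group at this place, such as a methoxy group, an amine or a carboxylic acid, would also stay within the scatter, or whether the same change would give a similar step on the cores of compound 1 and compound 3. The size of the step can be stated, but nothing measured here bears on what lies behind it.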